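Hydrogen for trifluoromethyl: what compound 4 may show

A few compounds are considered here, and "the series" means these few. Any claim that something is new, unique, unknown or untested is made for them only; others in the source may bear on it.

Compound 3 `CCC1(Cc2ccccc2)OS(=O)(=O)C=C1OCc1ccc(C(F)(F)F)cc1` is the starting point of this step. In an ADME assay on HEL cells (Homo sapiens) for cytotoxicity, with a stated time of 3 days (on this read-out higher numbers stand for lower toxicity in this test and lower numbers for higher toxicity in this test), compound 3 gives >= 16000 nM, which is a limit of the assay rather than a number. The two other compounds in the set also stand at limits. Compound 1 `CCC1(Cc2ccccc2)OS(=O)(=O)C=C1OC(c1ccccc1)c1ccccc1` in this assay gives >= 80000 nM, a limit. Compound 2 `CCC1(CC)OS(=O)(=O)C=C1OCc1ccccc1` in this assay gives > 400000 nM, likewise a limit. Among the compounds with values here, compound 3 therefore stands only at a limit, and no compound in the set has a numerical value against which it could be ranked.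

Compound 4 `CCC1(Cc2ccccc2)OS(=O)(=O)C=C1OCc1ccccc1` differs from compound 3 in one place: hydrogen in place of trifluoromethyl on an aromatic carbon. Within the data shown here, no pair of measured compounds differs by this change alone, so no measured step sets the size of the shift. The step that the limit leaves unreadable from compound 3 to compound 4 is expected to be small, toward lower toxicity if anything, and may not exceed the scatter. Compound 4 in this assay is estimated at 80000 nM, within 16000 nM to 400000 nM, most probably reported once more as a limit.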

Compound 4, minimum cytotoxic concentration: >= 50000 nM
Compound 4: no number, only a limit; the forecaster's own chance of this, stated with the estimate: 80%; the middle value lies beyond the limit too.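

Compound 4, like compound 1, compound 2 and compound 3, stands only at a limit in this assay, so none of its steps from those compounds can be read. The compounds shown leave open whether any of these single changes shifts the minimum cytotoxic concentration at all.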